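The compounds below may be only part of what the source reports. "The series", "measured", "known", "first", "only" and "open" are said of these compounds alone.

Measured in a functional assay on the whole organism (strain Wistar) for inhibition, with Rattus norvegicus as the target, read by paw edema, with stated times of 30 min and 3 h, at a dose of 200 mg/kg by the oral route; a higher number here means more inhibition at the dose given (going by the name of the read-out), a lower number less inhibition:
compound 1, `O=C(O)c1cc(-n2c(-c3ccccc3)cc3c2CCCC3)ccc1O`, gives >= 60%
compound 2, `CC(=O)Oc1ccc(-n2c(-c3ccccc3)cc3c2CCCC3)cc1C(=O)O`, gives 50%
compound 3, `COc1ccc(-n2c(-c3ccccc3)cc3c2CCCC3)cc1C(=O)O`, gives 40%

Among the measured compounds shown here, the value of compound 1 is a limit of this assay rather than a number, and it is the one value that sits at the limit of >= 60% in this assay, at which 1 of the 3 values shown sits. Compound 2 carries an acetyl on the oxygen of the hydroxy group, and the step there is a number at least 10 percentage points lower from compound 1 to compound 2 (that floor lies within the scatter). Compound 3 carries a methyl on that oxygen, and the step is a number at least 20 percentage points lower from compound 1 to compound 3 (beyond the scatter). Between the two capped compounds the step is a number 10 percentage points lower from compound 2 to compound 3 (within the scatter).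

Compound 4, `O=C(O)c1cc(-n2c(-c3ccccc3)cc3c2CCCC3)cc(Br)c1O`, differs from compound 1 by bromo in place of hydrogen on an aromatic carbon. The hydroxy group itself remains free in compound 4. For the measured compounds named here, none of the measured steps alters an aromatic carbon; each of them changes only the oxygen, so none bears directly on this change. With the hydroxy group kept as in compound 1, compound 4 is expected to stay close to compound 1, so a number no higher from compound 1 to compound 4 (the limit leaves the size open) is expected to fall within the scatter. Compound 4 is therefore estimated at 60%, in a range from 45% to 75%.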

Compound 4, a percentage reported as inhibition, in the whole organism at one dose (the size of the read-out at that dose, not a potency): 0%
Beside the measured number, compound 4's estimate is 60 percentage points above it; the measured number lies below the stated range.
By their numbers in this assay, from the lowest: compound 4; then compounds 3 and 2 (each within the scatter of the next). At a limit, above all of these: compound 1.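

Bromo in place of hydrogen on this aromatic carbon, ortho to a hydroxy group and meta to a carboxy group, gives in this assay a number at least 60 percentage points lower from compound 1 to compound 4 (beyond the scatter). The earlier steps shown here all changed the oxygen, whereas compound 4 keeps the hydroxy group free, so a free hydroxy group alone does not preserve the read-out once this carbon is changed. The value of compound 1, >= 60%, is a limit: the limit of >= 60% in this assay, at which 1 of the 4 values shown sits.

Whether the loss belongs to bromo in particular stays open, since the compounds shown do not tell how chloro, methyl or an amine on this same carbon would read in this assay. They also give no cause for the loss, and they leave open whether bromo on another carbon of this ring would give the same result.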